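The source may hold more compounds than are shown below. What is called first, only, known or untested is meant among the compounds shown, and "the series" means these compounds.

Working notes on the ethoxycarbonyl side of the series. In a functional assay on MCF7 cells (Homo sapiens) for antiproliferative activity, read by MTT assay, with a stated time of 48 h (a higher number here means a weaker inhibitor, a lower number a stronger inhibitor), compound 1 `CCOC(=O)/C(=C/c1ccccc1)CN1C(=O)[C@@H](OC)[C@H]1c1cccc([N+](=O)[O-])c1` gives 19900 nM. Compound 3 `CCOC(=O)/C(=C/c1ccccc1)CN1C(=O)[C@@H](OC)[C@H]1c1ccc(F)cc1` gives 18800 nM, and a 1.1-fold lower number from compound 1 to compound 3 (0.02 log units; within the scatter) means the two cannot be separated. Compound 2 `CCOC(=O)/C(=C/c1ccccc1)CN1C(=O)[C@@H](OC)[C@H]1c1ccccc1Br` gives 5790 nM, and a 3.4-fold lower number from compound 1 to compound 2 (0.54 log units; beyond the scatter) sets it apart from compound 1. Compound 1 therefore sits level with compound 3, with compound 2 the only clear departure among the measured compounds.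

The next change leads to compound 4 `COC(=O)/C(=C/c1ccccc1)CN1C(=O)[C@@H](OC)[C@H]1c1cccc([N+](=O)[O-])c1`: hydrogen in place of methyl on a saturated chain carbon bound to an oxygen next to a carbonyl group. This is hydrogen in place of methyl on a saturated chain carbon bound to an oxygen next to a carbonyl group, so ethoxycarbonyl becomes methoxycarbonyl.

Within the data shown here, no measured step touches this place. All three, including a 3.2-fold higher number from compound 2 to compound 3 (0.51 log units; beyond the scatter), exchange the substituted phenyl on a saturated ring carbon, and even those stay modest. Among the measured compounds shown here, they bear on the change only by showing how little this assay has moved across the series so far. With no direct evidence for this change, no step beyond the scatter is expected in this assay.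

The estimated step is a 1.1-fold lower number from compound 1 to compound 4 (0.04 log units; within the scatter), with no clear direction expected. Compound 4 is estimated at 18000 nM, with an expected range of 8000 nM to 40000 nM.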

Compound 4, half-maximal inhibitory concentration: 15000 nM
Estimate against measurement, compound 4: 1.2-fold (0.08 log units) above; the measured number falls inside the stated range.
By their numbers in this assay, from the lowest: compound 2; then compounds 4, 3 and 1 (each within the scatter of the next).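

With this assay as the read-out, this position now has its first direct reading: ethoxycarbonyl to methoxycarbonyl gives a 1.3-fold lower number from compound 1 to compound 4 (0.12 log units; within the scatter) and so leaves the two compounds inseparable. Among these compounds, the earlier steps all exchanged the substituted phenyl on a saturated ring carbon, which remains the only kind of change with steps printed beyond the scatter, while loss of this single methyl produces no resolvable shift on the 3-nitrophenyl background. No supporting data speak to the reason for this result.

This single step covers only the move from ethyl to methyl, so a longer chain such as propyl or butyl in place of ethyl, a free carboxylic acid, or a primary amide in place of the ethoxycarbonyl group remains untested in the compounds shown. Also open, going by these compounds, is whether methoxycarbonyl would stay level with ethoxycarbonyl on the 2-bromophenyl or 4-fluorophenyl backgrounds, as the reading here rests on one matched pair carrying 3-nitrophenyl.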